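Swapping the Aryl Group on the Ring Nitrogen

The source may report more compounds than this note shows. Statements on the series, on what has been measured and on what is new or still open speak of the compounds shown alone.

Compound 1, `COc1c(F)cccc1N1C(=O)CSC1c1cccc(C(=O)NCCCCc2ccccc2)c1`: 12%
Compound 2, `Cc1cccc(N2C(=O)CSC2c2cccc(C(=O)NCCCCc3ccccc3)c2)c1`: 39%

Both compounds share one core and differ only in the aromatic group carried by the amide-type nitrogen in the five-membered ring. In a functional assay on U2OS cells (Homo sapiens) for inhibition, read by CCK-8 assay, with a stated time of 72 h, tested at 1 uM (on this read-out higher numbers stand for more inhibition at the one concentration tested (going by the name of the read-out) and lower numbers for less inhibition), compound 1 gives 12%. In the same this assay compound 2 gives 39%, the highest of the two numbers recorded. Among the measured compounds shown here, the single step between them, a number 27 percentage points higher from compound 1 to compound 2 (beyond the scatter), shows that exchanging the group on this nitrogen can move the read-out well beyond the scatter.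

Compound 3, `O=C(NCCCCc1ccccc1)c1cccc(C2SCC(=O)N2c2ccccc2F)c1`, has not yet been measured. It differs from compound 2 in one place: 2-fluorophenyl in place of 3-methylphenyl on an amide-type nitrogen in a ring. For the measured compounds named here, the only step that bears on this change is the one just described, and it points to this position as sensitive, but it does not say which way a 2-fluorophenyl would move the number. Compound 3 is therefore expected to show a step of a number 14 percentage points lower from compound 2 to compound 3 (beyond the scatter) in this assay, most likely downward and of modest size, with wide uncertainty. The estimate for compound 3 is 25%, with a range from 5% to 50%.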

Compound 3, a percentage reported as inhibition, at one concentration (the size of the read-out at that concentration, not a potency): 38%
Compound 3: the middle estimate sits 13 percentage points below what was measured, and the stated range covers the measured number.
By their numbers in this assay, from the lowest: compound 1; then compounds 3 and 2 (each within the scatter of the next).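

Exchanging 3-methylphenyl for 2-fluorophenyl on the amide-type nitrogen in the ring gives a number 1 percentage points lower from compound 2 to compound 3 (within the scatter) in this assay so on this read-out the two groups cannot be told apart, even though they carry different substituents at different places on the phenyl ring. Replacing 3-fluoro-2-methoxyphenyl with 2-fluorophenyl gives a number 26 percentage points higher from compound 1 to compound 3 (beyond the scatter) and thus shows a second group, besides 3-methylphenyl, that gives a clearly higher number than the group in compound 1. Among these three compounds, a fluorine on the phenyl ring does not always go with the low number, as compound 3 carries one as well, so the low number stays tied to the whole 3-fluoro-2-methoxyphenyl group rather than to any one part of it.

No measurement at hand explains why these groups give the numbers they do. Also open, going by these compounds, is how a plain phenyl, a 2-methoxyphenyl, or a phenyl bearing an amine or a carboxylic acid would behave on this nitrogen, and whether any such group could take the number clearly beyond that of compound 2.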